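Aryl ether linker variants on the shared core

The compounds below may be only part of what the source reports. "The series", "measured", "known", "first", "only" and "open" are said of these compounds alone.

Measured so far in an assay on isolated protein for agonist activity at Bile acid receptor (Homo sapiens), read by FRET; on this read-out higher numbers stand for larger maximal responses and lower numbers for smaller maximal responses:
compound 1 `CC(Nc1ccc(C(=O)O)cc1)c1ccc(OCc2c(-c3c(Cl)cccc3Cl)noc2C2CC2)nc1C(F)(F)F`, 99%
compound 2 `O=C(O)c1ccc(OCc2ccc(OCc3c(-c4c(Cl)cccc4Cl)noc3C3CC3)nc2C(F)(F)F)cc1`, 86%

Compound 2 has the lower of the two numbers in this assay, with compound 1 the nearer and higher one. Within the data shown here, the single measured step, a number 13 percentage points lower from compound 1 to compound 2 (beyond the scatter), is the only guide on the linker region of the shared core.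

Compound 3 `CC(Oc1cccc(C(=O)O)c1)c1ccc(OCc2c(-c3c(Cl)cccc3Cl)noc2C2CC2)nc1C(F)(F)F` has not been measured in this assay. Compared with compound 2 it carries 1-(3-carboxyphenoxy)ethyl in place of (4-carboxyphenoxy)methyl on an aromatic carbon. This change restores an ethyl-bearing linker, as in compound 1, while keeping the ether oxygen of compound 2 and shifting the carboxyl on the phenyl ring. The measured step from compound 1 to compound 2 was modest, so a step of similar or smaller size is expected here, more likely upward than downward, but not with confidence.

For compound 3 the expected value in this assay is 90% (range 70% to 105%), a step of a number 4 percentage points higher from compound 2 to compound 3 (within the scatter).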

Compound 3, largest response reached (reported as efficacy), in percent of the reference or control that the assay uses: 102%
The estimate for compound 3 lay 12 percentage points below the measured number; low and high end bracket the measured number.
By their numbers in this assay, from the lowest: compound 2; then compounds 1 and 3 (each within the scatter of the next).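

In this assay, 1-(3-carboxyphenoxy)ethyl in place of (4-carboxyphenoxy)methyl, on the aromatic carbon ortho to a trifluoromethyl group, gives a number 16 percentage points higher from compound 2 to compound 3 (beyond the scatter), so an ether oxygen in the linker does not by itself go with the lower number of compound 2. With a number 3 percentage points higher from compound 1 to compound 3 (within the scatter), this read-out does not separate 3-carboxyphenoxy from (4-carboxyphenyl)amino on the saturated chain carbon. No measured evidence on the origin of either step is available.

The step to compound 3 changes the linker and the place of the carboxylic acid together, and the compounds shown do not divide it between the two; 1-(4-carboxyphenoxy)ethyl or (3-carboxyphenoxy)methyl would bear on that. From the compounds shown here alone, whether a tetrazole in place of the carboxylic acid holds this response also remains open.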